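Methoxy added to the pyridin-2-yl group of compound 2

A few compounds are considered here, and "the series" means these few. Any claim that something is new, unique, unknown or untested is made for them only; others in the source may bear on it.

Compound 2 `C[C@@H](NC(=O)c1nc(-c2ccccn2)nc(O)c1O)C1CCCCC1` is the methyl congener of compound 1 `O=C(NCC1CCCCC1)c1nc(-c2ccccn2)nc(O)c1O` with the chain stereocentre drawn R; in an ADME assay on HeLa cells (Homo sapiens) for cytotoxicity (a higher number here means that more compound is tolerated, a lower number that less compound is tolerated), compound 2 gives 3200 nM, second highest of the three numbers. Compound 1 gives 3600 nM, and the step of a 1.1-fold lower number from compound 1 to compound 2 (0.05 log units; within the scatter) lies within the scatter. Compound 3 `C[C@H](NC(=O)c1nc(-c2ccccn2)nc(O)c1O)C1CCCCC1` gives 600 nM; the step of a 5.3-fold lower number from compound 2 to compound 3 (0.73 log units; beyond the scatter) is beyond the scatter and rests on (the fact that compounds 2 and 3 differ only in the configuration as drawn), and a 6.0-fold lower number from compound 1 to compound 3 (0.78 log units; beyond the scatter) matches it. Compound 4 `COc1ccnc(-c2nc(O)c(O)c(C(=O)N[C@H](C)C3CCCCC3)n2)c1` differs from compound 2 by methoxy in place of hydrogen on an aromatic carbon. Going by the values given here, none of the measured steps touches the pyridin-2-yl group; all concern the saturated chain carbon bound to the amide-type nitrogen. Among the compounds with values here, no step is therefore expected beyond the scatter, no change at the digits printed from compound 2 to compound 4 (within the scatter). For compound 4 the expected value is 3200 nM, range 1500 nM to 6800 nM.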

Compound 4, half-maximal cytotoxic concentration: 3000 nM
Beside the measured number, compound 4's estimate is 1.1-fold (0.03 log units) above it, within the range that was stated.
By their numbers in this assay, from the lowest: compound 3; then compounds 4, 2 and 1 (each within the scatter of the next).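

In this assay, the pyridin-2-yl group now has its first measured change: going to 4-methoxypyridin-2-yl, on the aromatic carbon opposite the ring nitrogen, gives a step within the scatter (a 1.1-fold lower number from compound 2 to compound 4 (0.03 log units; within the scatter)). This position therefore accepts methoxy in the R-drawn compound without a readable shift in the number. Nothing on record accounts for this step.

Open, going by these compounds, is whether an amine or a carboxylic acid at this position would also stay within the scatter of compound 2. Also open, on these data alone, is how methoxy would read on the S-drawn compound 3, at 600 nM.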